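This account rests on a few compounds, and the source may have more. Where it says the series, first, only, none or still open, it means among the compounds named here.

Measured so far in a functional assay on MCF7 cells (Homo sapiens) for antiproliferative activity; on this read-out higher numbers stand for weaker inhibition and lower numbers for stronger inhibition:
compound 1 `COc1ccc(Oc2ccc3cc(NC(=O)c4ccc(OC(C)=O)c(CC=C(C)C)c4)c(=O)oc3c2C)cc1` gives 18200 nM;
compound 2 `COc1ccc(Oc2ccc3cc(NC(=O)c4ccc(OC)c(-c5cccc(OC)c5)c4)c(=O)oc3c2C)cc1` gives > 100000 nM;
compound 3 `COc1cccc(Cc2ccc3cc(NC(=O)c4ccc(O)c(CC=C(C)C)c4)c(=O)oc3c2C)c1` gives 19700 nM.

For compound 2 the value is a limit of the assay and not a number: the limit of > 100000 nM in this assay, at which 1 of the 3 values shown sits. Compound 4 `COc1ccc(Cc2ccc3cc(NC(=O)c4ccc(OC)c(-c5cccc(OC)c5)c4)c(=O)oc3c2C)cc1` is compound 2 with one change, (4-methoxybenzyl in place of 4-methoxyphenoxy on an aromatic carbon). Compound 1 and compound 3 differ from each other in more than one place, and in this assay compound 1 gives 18200 nM while compound 3 gives 19700 nM; these two values lie within the usual scatter of each other. Among the measured compounds shown here, no step between measured compounds shows what the change from compound 2 to compound 4 does on its own. Compound 4 is therefore expected to remain weak, with the step from compound 2 to compound 4 estimated as an at least 1.1-fold lower number from compound 2 to compound 4 (0.04 log units; that floor lies within the scatter), not clearly beyond the scatter. Compound 4 is expected to give about 90000 nM, between 25000 nM and 300000 nM.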

Compound 4, half-maximal inhibitory concentration: > 100000 nM
Compound 4: only a limit was reported; the forecaster's own chance of this, stated with the estimate: 50%; middle value at least 1.1-fold (0.04 log units) from the limit.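

In this assay compound 4 gives > 100000 nM as a limit of the assay and not a number. Among the compounds shown here, compound 2 also sits at a limit, so no step between them can be read: the limit of > 100000 nM in this assay, at which 2 of the 4 values shown sit. The compounds shown leave open whether 4-methoxybenzyl in place of 4-methoxyphenoxy changes activity at all.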